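A few compounds are considered here, and "the series" means these few. Any claim that something is new, unique, unknown or untested is made for them only; others in the source may bear on it.

For the measured compounds named here, compound 1, with the structure `CC[C@@H](Nc1n[s+]([O-])nc1Nc1cccc(C(=O)N(C)C)c1O)c1cc(C(C)C)co1`, is the stronger of the two compounds measured so far in an assay on isolated protein for binding affinity to C-X-C chemokine receptor type 1 (Homo sapiens); a higher number here means a weaker inhibitor, a lower number a stronger inhibitor: compound 1 gives 61 nM. Going by the values given here, the only other measured compound, compound 2, has the structure `CC[C@@H](NC1=NS(=O)(=O)N=C1Nc1cccc(C(=O)N(C)C)c1O)c1ccccc1` and differs from compound 1 both in the side chain on the saturated chain carbon and in the shared core; in this assay compound 2 gives 8990 nM, a far higher number than that of compound 1, well beyond the scatter of repeated measurements. Because compound 2 changes two things at once, its value alone cannot tell how much of that gap comes from the side chain.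

Compound 3, with the structure `CC[C@@H](Nc1n[s+]([O-])nc1Nc1cccc(C(=O)N(C)C)c1O)c1ccccc1`, keeps the core of compound 1 and changes only the side chain: phenyl in place of 4-isopropylfuran-2-yl on a saturated chain carbon bound to a nitrogen on an aromatic ring and a saturated chain carbon. Among the compounds with values here, no measured pair isolates this change, so the size of the step is uncertain. A loss of binding strength beyond the scatter is expected, since compound 3 shares its side chain with the much weaker compound 2, yet a step as large as the whole gap to compound 2 is not expected. For compound 3 the estimated value is 300 nM, with a likely range from 60 nM to 2000 nM, which means an expected step from compound 1 to compound 3 of a 4.9-fold higher number from compound 1 to compound 3 (0.69 log units; beyond the scatter).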

Compound 3, inhibition constant: 1220 nM
Estimate against measurement, compound 3: 4.1-fold (0.61 log units) below, and the stated range covers the measured number.
By their numbers in this assay, from the lowest: compound 1; then compound 3; then compound 2.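

With the core of compound 1 held fixed, phenyl in place of 4-isopropylfuran-2-yl on this saturated chain carbon gives a 20-fold higher number from compound 1 to compound 3 (1.30 log units; beyond the scatter) in this assay, so the side chain at this position alone has a large effect on binding strength. The side chain does not account for the whole gap to compound 2, however: with phenyl in both, compound 3 gives 1220 nM, while compound 2, which differs from it only in the core, gives 8990 nM. No measurement here explains why the two side chains differ so strongly.

The compounds shown do not reveal which part of 4-isopropylfuran-2-yl carries the difference, the furan ring or the isopropyl group, and a furan-2-yl without the isopropyl group or a phenyl carrying an isopropyl group would help to separate the two. On these data alone, it also remains open how this position responds to side chains of other kinds, such as a thiophene ring, a cyclohexyl ring or a chain ending in an amine.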